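Ester, amide and nitrile on the shared ketone core

The source may report more compounds than this note shows. Statements on the series, on what has been measured and on what is new or still open speak of the compounds shown alone.

Compound 1 `COC(=O)c1cnc(C(=O)CCc2ccc(Oc3ccccc3)cc2)o1` gives 1.7 nM in an assay for inhibition of Fatty-acid amide hydrolase 1 (Rattus norvegicus); on this read-out higher numbers stand for weaker inhibition and lower numbers for stronger inhibition. Among the measured compounds shown here, compound 2 `NC(=O)c1cnc(C(=O)CCc2ccc(Oc3ccccc3)cc2)o1` gives 6.6 nM in this assay, the higher of the two numbers measured so far; the step of a 3.9-fold higher number from compound 1 to compound 2 (0.59 log units; beyond the scatter) separates them. Compound 3 `N#Cc1cnc(C(=O)CCc2ccc(Oc3ccccc3)cc2)o1` carries the change (cyano in place of carbamoyl on an aromatic carbon). For the measured compounds named here, only the step from compound 1 to compound 2 concerns this same group, and it swapped one carbonyl substituent for another, so it bears only loosely on a carbamoyl-to-cyano exchange. A modest step toward a lower number is therefore expected, a 2.6-fold lower number from compound 2 to compound 3 (0.42 log units; beyond the scatter). Compound 3 is estimated at 2.5 nM in this assay, within 0.8 nM to 8 nM.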

Compound 3, inhibition constant: 0.8 nM
The estimate for compound 3 lay 3.1-fold (0.49 log units) above the measured number; the range from low to high includes it.
By their numbers in this assay, from the lowest: compound 3; then compound 1; then compound 2.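

Cyano gives the lowest number of the three groups at this position in this assay, with an 8.3-fold lower number from compound 2 to compound 3 (0.92 log units; beyond the scatter) and a 2.1-fold lower number from compound 1 to compound 3 (0.33 log units; beyond the scatter). A carbonyl in this substituent is therefore not needed for a low number among these compounds, and the earlier ester and amide pair could not show this. Nothing measured here accounts for the order of the three groups.

Still open, from the compounds shown here alone, is where a carboxylic acid, an amine or a bare hydrogen at this position would fall. Also open, going by these compounds, is whether the order holds with a longer chain on the ketone.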